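A Pyridine Swap on Compound 1

This account rests on a few compounds, and the source may have more. Where it says the series, first, only, none or still open, it means among the compounds named here.

In a physicochemical assay for solubility, at pH 6.8 (on this read-out higher numbers stand for higher solubility and lower numbers for lower solubility), compound 1 (`COc1ccc(NC(=O)Nc2cnc3ccc(C#N)cc3c2N(C)C2CCOCC2)cc1Cl`) gives 27000 nM and holds the lower of the two numbers available. Compound 2 (`COc1ncc(NC(=O)Nc2cnc3ccc(F)cc3c2N(C)C2CCCN(C)C2)cc1Cl`) gives 61000 nM as the higher number, a gap beyond the usual scatter. Compound 3 (`COc1ccc(NC(=O)Nc2cnc3ccc(Br)cc3c2)cc1Cl`) reports only a limit, < 4000 nM and no number.

Compound 4 (`COc1ncc(NC(=O)Nc2cnc3ccc(C#N)cc3c2N(C)C2CCOCC2)cc1Cl`) departs from compound 1 in one place (5-chloro-6-methoxypyridin-3-yl in place of 3-chloro-4-methoxyphenyl on an amide-type nitrogen), with 5-chloro-6-methoxypyridin-3-yl in place of 3-chloro-4-methoxyphenyl on an amide-type nitrogen. Among the compounds with values here, no measured pair shows this change alone. Compound 2 carries the same 5-chloro-6-methoxypyridin-3-yl group and gives 61000 nM on a different remainder, so this assay is expected to show only a modest upward step, near the edge of the scatter. The estimated step (a 1.6-fold higher number from compound 1 to compound 4 (0.19 log units; within the scatter)) is therefore small and uncertain in size. Compound 4 is estimated at 42000 nM within an expected range of 18000 nM to 100000 nM in this measurement.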

Compound 4, solubility: < 4000 nM
Compound 4 ended at the assay's limit; the forecaster's own chance of this, stated with the estimate: 5%; middle value at least 10-fold (1.02 log units) from the limit.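

Exchanging 3-chloro-4-methoxyphenyl for 5-chloro-6-methoxypyridin-3-yl on the amide-type nitrogen of compound 1 gives, in this assay, an at least 6.7-fold lower number from compound 1 to compound 4 (0.82 log units; beyond the scatter). Compound 4 reports a limit, < 4000 nM, and not a number. Compound 2 carries the same group and gives 61000 nM on a different remainder. The group alone therefore does not place a compound at the limit, and on the remainder of compound 1 the step can be read only as a bound: the limit of < 4000 nM in this assay, at which 2 of the 4 values shown sit.

The compounds shown leave open how far compound 4 actually falls, and whether the same exchange has the same outcome on any other remainder. They also leave open how this assay responds on this remainder when an amine such as dimethylamino replaces the methoxy group of the 5-chloro-6-methoxypyridin-3-yl group.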